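Compound 3 to compound 4: methyl for oxetan-3-yl

The compounds below may be only part of what the source reports. "The series", "measured", "known", "first", "only" and "open" are said of these compounds alone.

In an ADME assay on microsomes from liver (Homo sapiens) for pharmacokinetics, read by LC-MS, with a stated time of 60 min, tested at 1 uM (a higher number here means faster removal of the compound, a lower number slower removal), compound 1 (`O=C(NCc1ccc(S(=O)(=O)C2CCCCC2)cc1)N1Cc2ccncc2C1`) gives 16 mL/min/kg with cyclohexyl on the sulfonyl sulfur. Compound 2 (`CCC(=O)N1CCC(S(=O)(=O)c2ccc(CNC(=O)N3Cc4ccncc4C3)cc2)CC1`) gives 11 mL/min/kg with 1-propanoylpiperidin-4-yl on that sulfur. Compound 3 (`O=C(NCc1ccc(S(=O)(=O)C2CCN(C3COC3)CC2)cc1)N1Cc2ccncc2C1`) gives 10 mL/min/kg with 1-(oxetan-3-yl)piperidin-4-yl there, which places it within the scatter of both other compounds.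

Compound 4 (`CN1CCC(S(=O)(=O)c2ccc(CNC(=O)N3Cc4ccncc4C3)cc2)CC1`) is still unmeasured. It differs from compound 3 by methyl in place of oxetan-3-yl on an amine nitrogen in a ring, and the count reads methyl in place of oxetan-3-yl on an amine nitrogen in a ring with the rest of the structure unchanged.

The nearest evidence is the exchange on that same nitrogen, a 1.1-fold lower number from compound 2 to compound 3 (0.04 log units; within the scatter) as measured. The two exchanges on the sulfonyl sulfur, a 1.5-fold lower number from compound 1 to compound 2 (0.16 log units; within the scatter) and a 1.6-fold lower number from compound 1 to compound 3 (0.20 log units; within the scatter) as measured, are also small. Going by the values given here, no compound with methyl on this nitrogen has been measured, so the data offer only this indirect guide.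

No step beyond the scatter is therefore expected, and the estimated step is a 1.2-fold higher number from compound 3 to compound 4 (0.08 log units; within the scatter) for now. For compound 4 the expected clearance is 12 mL/min/kg with an estimated range of 6 mL/min/kg to 22 mL/min/kg as the working figure.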

Compound 4, clearance: 11 mL/min/kg
Beside the measured number, compound 4's estimate is 1.1-fold (0.04 log units) above it; low and high end bracket the measured number.
By their numbers in this assay, from the lowest: compounds 3, 2, 4 and 1 (each within the scatter of the next).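

With compound 4, the amine nitrogen in the six-membered ring has now been read with methyl as well as with oxetan-3-yl and propanoyl, and in this assay the exchanges at this position give a 1.1-fold higher number from compound 3 to compound 4 (0.04 log units; within the scatter) and no change at the digits printed from compound 2 to compound 4 (within the scatter), both within the scatter. Going from oxetan-3-yl, with its 4 heavy atoms and four-membered ring, to methyl, with 1 heavy atom and no ring, removes the one hydrogen-bond acceptor of that group without a step beyond the scatter, so in these compounds neither that ring nor the acceptor is needed to hold the number in this range; the exchange on the sulfonyl sulfur, seen in a 1.5-fold lower number from compound 1 to compound 4 (0.16 log units; within the scatter), also stays within the scatter, as do the two earlier exchanges there, and no measurement at hand gives a reason for these small steps.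

Going by these compounds, whether a free amine hydrogen on this nitrogen, a longer alkyl chain or a carboxylic acid on a chain there would give a step beyond the scatter stays open. These compounds also leave open whether an exchange on the urea or on the shared core would move the number more than any exchange on the sulfonyl side has so far.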